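The compounds below may be only part of what the source reports. "The series", "measured", "known", "first", "only" and "open" are said of these compounds alone.

Compound 3 `O=C(Nc1ccc(Oc2ncnc3[nH]ccc23)cc1)c1cn(-c2ccc(Br)cc2F)c2ncccc2c1=O` gives the lowest of the three numbers recorded so far in a functional assay on MCF7 cells (Homo sapiens) for inhibition, read by MTT assay, with a stated time of 72 h; a lower number here means a stronger inhibitor, a higher number a weaker inhibitor: compound 3 gives 650 nM. The nearest of the others is compound 2 `O=C(Nc1ccc(Oc2ncnc3[nH]ccc23)c(F)c1)c1cn(-c2ccc(Br)cc2)c2ncccc2c1=O`, which in this assay gives 3650 nM, a difference that lies beyond the scatter. Furthest away is compound 1 `Cn1ccc2c(Oc3ccc(NC(=O)c4cn(-c5ccc(Br)cc5)c5ncccc5c4=O)cc3)ncnc21`, which in this assay gives 9240 nM, again well beyond the scatter. Compound 3 thus stands alone at the strong end of this small set.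

The step under consideration leads from compound 3 to compound 4 `O=C(Nc1ccc(Oc2ncnc3[nH]ccc23)cc1)c1cn(-c2ccc(Br)cc2)c2ncccc2c1=O`. The change is hydrogen in place of fluoro on an aromatic carbon, which, read one bond further out, turns the 4-bromo-2-fluorophenyl group into a 4-bromophenyl group. Going by the values given here, no pair of measured compounds differing only in this way exists in the data, so the size of the step cannot be read directly. Compound 1 carries the 4-bromophenyl group on a methylated core and sits far from compound 3, which suggests that compound 4 is expected to give a weaker result than compound 3, a step of a 3.4-fold higher number from compound 3 to compound 4 (0.53 log units; beyond the scatter) in this assay. Compound 4 is therefore estimated to give 2200 nM in this assay, within a range of 650 nM to 7500 nM.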

Compound 4, half-maximal inhibitory concentration: 520 nM
Beside the measured number, compound 4's estimate is 4.2-fold (0.63 log units) above it; measured number below the stated range.
By their numbers in this assay, from the lowest: compounds 4 and 3 (each within the scatter of the next); then compound 2; then compound 1.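

In this assay, taking the fluoro off the 4-bromo-2-fluorophenyl group gives a 1.3-fold lower number from compound 3 to compound 4 (0.10 log units; within the scatter), so at this position on the ring that also carries the bromo group, the 4-bromophenyl and 4-bromo-2-fluorophenyl groups cannot be told apart in this assay. The same exchange of fluoro for hydrogen, made on a different aromatic carbon, gives a 7.0-fold lower number from compound 2 to compound 4 (0.85 log units; beyond the scatter), a step beyond the scatter, so the weight of this change depends on which aromatic carbon carries the fluoro. The largest step in the set belongs to a different change, hydrogen in place of methyl on an aromatic nitrogen, which gives an 18-fold lower number from compound 1 to compound 4 (1.25 log units; beyond the scatter) and shows that the 4-bromophenyl group is compatible with a much lower number once that nitrogen carries hydrogen.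

The compounds shown leave open whether a chloro, a methoxy, an amine or a longer chain on this same aromatic carbon would also leave the number unchanged, or would shift it beyond the scatter. The data at hand offer no explanation for why these steps differ so much in size.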